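The compounds below may be only part of what the source reports. "The series", "measured", "known", "first", "only" and "open" are said of these compounds alone.

Measured so far:
- compound 1 `CCCCCCCCCCN(NC(=O)COC)C(=O)CCCCCCCCC` — > 125000 nM
- compound 2 `CCCCCCCCCCCCCCN(NC(=O)COC)C(=O)OC(C)(C)C` — 41900 nM

Both compounds were run in a functional assay on HeLa cells (Homo sapiens) for cytotoxicity, with a stated time of 72 h; a higher number here means that more compound is tolerated, a lower number that less compound is tolerated. For compound 1 the reading is a limit of the assay, > 125000 nM, not a number. Among the measured compounds shown here, compound 2 is the only compound of the pair that gives a number, 41900 nM. The other value shown, that of compound 1, is a limit, as summed up in the limit of > 125000 nM in this assay, at which 1 of the 2 values shown sits. For the measured compounds named here, compound 1 and compound 2 differ in more than one place, so no single step connects them and their two values can only be set side by side.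

Compound 3 `CCCCCCCCCCN(NC(=O)COC)C(=O)OC(C)(C)C` is not yet measured. It differs from compound 2 by hydrogen in place of butyl on a saturated chain carbon, ten or more bonds along the chain from an amide-type nitrogen. Going by the values given here, no measured step of this kind exists. Given that compound 1, which also carries the shorter chain, sits at the limit > 125000 nM, a step towards more tolerated compound is expected, in this assay modest and possibly within the scatter. For compound 3 the expected value in this assay is 80000 nM, within 25000 nM to 250000 nM. This estimate means an expected step of a 1.9-fold higher number from compound 2 to compound 3 (0.28 log units; within the scatter).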

Compound 3, half-maximal cytotoxic concentration: 104000 nM
The estimate for compound 3 lay 1.3-fold (0.11 log units) below the measured number; the measured number falls inside the stated range.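

In this assay, the series now has its first step that changes one place on the chain, a 2.5-fold higher number from compound 2 to compound 3 (0.39 log units; beyond the scatter), so hydrogen in place of butyl on a saturated chain carbon, ten or more bonds along the chain from an amide-type nitrogen, moves the number beyond the scatter, towards more compound tolerated. Among the compounds shown here, with the shorter chain held constant, the change at the carbonyl carbon can also be read for the first time, as tert-butoxy in place of nonyl gives an at least 1.2-fold lower number from compound 1 to compound 3 (0.07 log units; that floor lies within the scatter), and this floor does not separate the two compounds from the scatter. The reading for compound 1 is a limit of the assay, and the step from it gives a floor only, not a size: the limit of > 125000 nM in this assay, at which 1 of the 3 values shown sits.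

Only one chain change is shown, made with tert-butoxy on the carbonyl carbon, and it remains open whether the same shift holds with nonyl there or extends to a longer chain. Also open, going by these compounds, is how this assay responds when an amine or a carboxylic acid takes the place of tert-butoxy on the carbonyl carbon.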